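The source may hold more compounds than are shown below. What is called first, only, known or untested is meant among the compounds shown, and "the series" means these compounds.

Measured compounds in a functional assay on MDA-MB-435 cells (Homo sapiens) for cytotoxicity, read by sulforhodamine B assay, with a stated time of 48 h; a higher number here means a weaker inhibitor of growth, a lower number a stronger inhibitor of growth:

compound 1, `Nc1nc(Cl)c2ncn(Cc3ccc(CCl)cc3)c2n1`: 42700 nM
compound 2, `ClCc1cccc(Cn2cnc3c(Cl)nc(Cl)nc32)c1`: 3230 nM
compound 3, `ClCc1ccc(Cn2cnc3c(Cl)nc(Cl)nc32)cc1`: 25100 nM

Compound 2 gives the lowest of the three numbers; its gaps to compound 3 and to compound 1 are both beyond the scatter. Compound 2 and compound 3 are built from the same atoms joined differently, and the difference between the two cores is not broken down here.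

Compound 3 and compound 1 differ in one place, (amino in place of chloro on an aromatic carbon). The step of a 1.7-fold higher number from compound 3 to compound 1 (0.23 log units; within the scatter) is within the scatter, so these two values cannot be ordered.

Compound 4, `Nc1nc(Cl)c2ncn(Cc3cccc(CCl)c3)c2n1`, is not yet measured. It stands to compound 2 as compound 1 stands to compound 3: amino in place of chloro on an aromatic carbon. The place lines of the two changes agree word for word, so the change is the same. Within the data shown here, the expectation for compound 4 rests on the one prior instance of this change, the step of a 1.7-fold higher number from compound 3 to compound 1 (0.23 log units; within the scatter), and on the value of compound 2, 3230 nM. The estimated step is a 1.7-fold higher number from compound 2 to compound 4 (0.23 log units; within the scatter). Compound 4 is thus expected to give 5500 nM in this assay, with an estimated range from 2200 nM to 14000 nM.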

Compound 4, concentration for total growth inhibition: 22400 nM
Beside the measured number, compound 4's estimate is 4.1-fold (0.61 log units) below it; measured number above the stated range.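

In this assay, amino in place of chloro on an aromatic carbon gives a 6.9-fold higher number from compound 2 to compound 4 (0.84 log units; beyond the scatter), a weakening of growth inhibition on the core of compound 2. The change does not carry over from one core to the other at a single size: the same change on two cores in this assay, a 1.7-fold higher number (0.23 log units; within the scatter) from compound 3 to compound 1 and a 6.9-fold higher number (0.84 log units; beyond the scatter) from compound 2 to compound 4, 4.1-fold (0.61 log units) apart, beyond the scatter of two such steps. A step taken on one of these cores is therefore a poor guide to the step on the other, but two pairs give no general rule, and they do not show what sets the gap between the steps.

Still open, on these data alone, is whether a methoxy group or a methylamino group in place of chloro at this position would differ between the two cores as amino does. Also open, as far as these compounds go, is whether the gap between the cores would remain with a hydroxymethyl group in place of the chloromethyl group carried by all four compounds.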